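The source may hold more compounds than are shown below. What is called first, only, known or untested is meant among the compounds shown, and "the series" means these compounds.

Measured compounds:
compound 1, `Cc1nc(C)c(C(=O)Oc2ccccc2/C=C/C(=O)O)nc1C`: 45.7%
compound 2, `COc1ccc(/C=C/C(=O)O)c(OC(=O)c2nc(C)c(C)nc2C)c1`: 39.7%
compound 3, `Cc1nc(C)c(C(=O)Oc2ccc(/C=C/C(=O)O)cc2)nc1C`: 34.2%

In a functional assay on EA.hy 926 cells (Homo sapiens) for cytotoxicity, read by MTT assay, with stated times of 24 h and 12 h, tested at 12.5 uM (a higher number here means a stronger effect of the compound at the concentration tested, a lower number a weaker effect), compound 1 holds the highest of the three numbers. The step of a number 6 percentage points lower from compound 1 to compound 2 (within the scatter) is within the scatter, so compound 1 and compound 2 are not told apart; compound 3 lies beyond the scatter below compound 1. Compound 4, `Cc1nc(C)c(C(=O)Oc2ccc(Cl)cc2/C=C/C(=O)O)nc1C`, differs from compound 1 by chloro in place of hydrogen on an aromatic carbon. Among the compounds with values here, the only measured step that bears on it is the one placing a methoxy on an aromatic carbon of the same phenyl, which stayed within the scatter from compound 1 to compound 2. The expected step of a number 1.7 percentage points lower from compound 1 to compound 4 (within the scatter) is therefore small, with no clear direction. Compound 4 is estimated at 44%, between 30% and 58%.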

Compound 4, a percentage reported as activity, at one concentration (the size of the read-out at that concentration, not a potency): 6.9%
Estimate against measurement, compound 4: 37.1 percentage points above, outside the stated range (below it).
By their numbers in this assay, from the lowest: compound 4; then compounds 3, 2 and 1 (each within the scatter of the next, the first and the last beyond it).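

With chloro in place of hydrogen on this aromatic carbon, meta to a 2-carboxyethenyl group and para to a large group, this assay gives a number 38.8 percentage points lower from compound 1 to compound 4 (beyond the scatter). The methoxy change on another carbon of that ring, a number 6 percentage points lower from compound 1 to compound 2 (within the scatter), gave no warning of a change of this size, so a single added atom here can matter greatly. Nothing available explains this fall.

Going by these compounds, what fluoro, methyl or an amine on this same carbon would give stays open, and with it whether the fall belongs to chloro itself or to any group placed here. Also open, on these data alone, is what chloro would do on another carbon of the ring.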